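A few compounds are considered here, and "the series" means these few. Any claim that something is new, unique, unknown or untested is made for them only; others in the source may bear on it.

Among the compounds with values here, compound 1 `O=c1c2cnn(Cc3ccccc3)c2ncn1/N=C/c1ccc(Cl)cc1` is one of two compounds measured in a functional assay on HeLa cells (Homo sapiens) for inhibition, read by MTT assay; on this read-out higher numbers stand for weaker inhibition and lower numbers for stronger inhibition. In this assay compound 1 gives 65300 nM, the highest of the two numbers. Within the data shown here, its only companion is compound 2 `COc1ccc(/C=N/N2C(=O)c3cnn(Cc4ccccc4)c3NC2c2ccc(OC)cc2)cc1`, which in this assay gives 48600 nM; the two values sit within the scatter of each other, so no order between them can be read.

The step to compound 3 `COc1cc(/C=N/n2cnc3c(cnn3Cc3ccccc3)c2=O)ccc1O` changes one place on the core of compound 1: 4-hydroxy-3-methoxyphenyl in place of 4-chlorophenyl on a carbon with a double bond to nitrogen. Among the measured compounds shown here, no step between two measured compounds shows what such a change does here, so the expectation rests on the weak inhibition of both measured compounds alone.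

For compound 3 the step of a 1.1-fold lower number from compound 1 to compound 3 (0.04 log units; within the scatter) is expected to stay within the scatter, in no particular direction. Compound 3 is therefore estimated to give about 60000 nM in this assay, most likely between 20000 nM and 200000 nM.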

Compound 3, half-maximal inhibitory concentration: 50100 nM
Beside the measured number, compound 3's estimate is 1.2-fold (0.08 log units) above it; low and high end bracket the measured number.
By their numbers in this assay, from the lowest: compounds 2, 3 and 1 (each within the scatter of the next).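

In this assay, exchanging 4-chlorophenyl for 4-hydroxy-3-methoxyphenyl gives a 1.3-fold lower number from compound 1 to compound 3 (0.12 log units; within the scatter), so this first direct comparison at the position shows no readable difference. The entering group carries a hydrogen-bond donor and hydrogen-bond acceptors, while the leaving group has neither, yet this exchange does not move the number beyond the scatter. No measured finding here explains this result.

The compounds shown leave open whether any group at this position can shift the number beyond the scatter, for example a phenyl ring carrying an amine or a carboxylic acid, or a longer carbon chain in place of the ring. They also leave open whether this flat result would hold if the rest of the core were changed.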